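Trifluoromethyl replacing methoxy on the aryl ring

The compounds below may be only part of what the source reports. "The series", "measured", "known", "first", "only" and "open" are said of these compounds alone.

Measured compounds in an ADME assay on HepG2 cells (Homo sapiens) for cytotoxicity, read by MTT assay, with a stated time of 72 h; a lower number here means that less compound is tolerated, a higher number that more compound is tolerated:
compound 1 `O=[N+]([O-])c1c(CS(=O)(=O)c2ccccc2)nc2c(-c3ccccc3)cc(Cl)cn12` gives > 15600 nM, which is a limit of the assay.
compound 2 `COc1ccc(-c2cc(Cl)cn3c([N+](=O)[O-])c(CS(=O)(=O)c4ccccc4)nc23)cc1` gives > 3900 nM, which is a limit of the assay.
compound 3 `N#Cc1ccc(-c2cc(Cl)cn3c([N+](=O)[O-])c(CS(=O)(=O)c4ccccc4)nc23)cc1` gives > 3900 nM, which is a limit of the assay.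

Compound 2 stands only at a limit in this assay; the two other values shown are limits as well, one at the limit of > 15600 nM in this assay, at which 1 of the 3 values shown sits, and, together with compound 2, two at the limit of > 3900 nM in this assay, at which 2 of the 3 values shown sit. Compound 4 `O=[N+]([O-])c1c(CS(=O)(=O)c2ccccc2)nc2c(-c3ccc(C(F)(F)F)cc3)cc(Cl)cn12` differs from compound 2 by trifluoromethyl in place of methoxy on an aromatic carbon. Going by the values given here, no measured step shares this change. The steps a step that the two limits leave unreadable from compound 1 to compound 2, a step that the two limits leave unreadable from compound 1 to compound 3 and a step that the two limits leave unreadable from compound 2 to compound 3 are all left unreadable by the limits, so they give no size and no direction. Nothing measured therefore points to a step beyond the scatter from compound 2 to compound 4 in this assay, and compound 4 is expected to sit again at or beyond the limit, the expected step being a step that the limit leaves unreadable from compound 2 to compound 4. Compound 4 is estimated at 8000 nM, within 3900 nM to 30000 nM.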

Compound 4, half-maximal cytotoxic concentration: > 3900 nM
Compound 4: no number, only a limit; the forecaster's own chance of this, stated with the estimate: 80%; the middle value does not contradict the limit.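

In this assay compound 4 gives > 3900 nM, which is a limit of the assay, so its steps to compound 1, compound 2 and compound 3 cannot be read. The compounds shown leave open where the half-maximal cytotoxic concentration of any of the four lies, and whether the groups on the aryl ring change it at all.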